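Swapping Methyl for Fluoro on a Well-Tolerated Compound

The source may hold more compounds than are shown below. What is called first, only, known or untested is meant among the compounds shown, and "the series" means these compounds.

Compound 2 `Cc1ccc(NC(=O)C(=O)NC(c2nc(C)c(CO)s2)C2CCCCN2)c(F)c1` is the starting point, tested in an ADME assay on MT2 cells (Homo sapiens) for cytotoxicity, read by XTT assay, with a stated time of 4 days; a lower number here means that less compound is tolerated, a higher number that more compound is tolerated. Compound 2 gives > 109000 nM, which is a limit of the assay and not a number. Compound 1 `Cc1nc(C(NC(=O)C(=O)Nc2ccc(Cl)cc2)C2CCCNC2)sc1CO` gives > 81000 nM, which is also a limit. Going by the values given here, compound 3 `Cc1nc(C(NC(=O)C(=O)Nc2ccc(Cl)cc2)C2CCCN2)sc1CCO` gives 42000 nM, the only true number among the three.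

Compound 4 `Cc1nc(C(NC(=O)C(=O)Nc2ccc(F)cc2F)C2CCCCN2)sc1CO` differs from compound 2 in one place (fluoro in place of methyl on an aromatic carbon), with fluoro in place of methyl on an aromatic carbon. Among the compounds with values here, no measured pair shows this change, so no shift beyond the usual scatter is expected in this assay. The estimated step of an at least 1.0-fold lower number from compound 2 to compound 4 (0.03 log units; that floor lies within the scatter) stays within that scatter. Compound 4 is expected to give 100000 nM, with an estimated range of 50000 nM to 200000 nM.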

Compound 4, half-maximal cytotoxic concentration: > 110000 nM
Compound 4: no number, only a limit; the forecaster's own chance of this, stated with the estimate: 65%; at least 1.1-fold (0.04 log units) between middle value and limit.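

Compound 2 and compound 4 each give only a limit of the assay, not a number, and the step between them cannot be read. The compounds shown leave open whether this assay responds at all to fluoro in place of methyl on an aromatic carbon.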